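Methylating the hydrazone nitrogen of compound 2

The compounds below may be only part of what the source reports. "The series", "measured", "known", "first", "only" and "open" are said of these compounds alone.

Compound 2 `COc1cc(/C(=N/N)c2ccc3c(ccn3C)c2)cc(OC)c1OC` carries a free hydrazone on a shared core. In a functional assay on HL-60 cells (Homo sapiens) for cytotoxicity, read by XTT assay, with a stated time of 72 h (on this read-out lower numbers stand for stronger inhibition and higher numbers for weaker inhibition), compound 2 gives > 10000 nM, which is a limit of the assay and not a number. Compound 1 `CCn1ccc2cc(C(OC(C)=O)c3cc(OC)c(OC)c(OC)c3)ccc21` gives > 10000 nM in this assay, again only a limit. Compound 3 `CCn1ccc2cc(/C(=N\N)c3cc(OC)c(OC)c(OC)c3)ccc21` differs from compound 2 by a methyl in place of hydrogen on a saturated chain carbon bound to an aromatic nitrogen. In this assay compound 3 gives > 1000 nM, also a limit. For the measured compounds named here, the only single-point step, a step that the two limits leave unreadable from compound 2 to compound 3, cannot be read, since compound 3 sits at the limit of > 1000 nM in this assay, at which 1 of the 3 values shown sits, while compound 2 and compound 1 sit at the limit of > 10000 nM in this assay, at which 2 of the 3 values shown sit. Compound 4 `CN/N=C(/c1cc(OC)c(OC)c(OC)c1)c1ccc2c(ccn2C)c1` differs from compound 2 by methyl in place of hydrogen on an amine nitrogen. No measured step touches this nitrogen, so nothing among these compounds points to a gain in potency from it, and compound 4 is expected to remain weak in this assay, with an estimated step that the limit leaves unreadable from compound 2 to compound 4 that is within the scatter. The estimate for compound 4 is 15000 nM, between 3000 nM and 60000 nM, most likely reported again as a limit.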

Compound 4, half-maximal inhibitory concentration: > 1000 nM
Compound 4: no number, only a limit (the forecaster's own chance of this, stated with the estimate: 75%); the middle value lies beyond the limit too.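

In this assay compound 4 gives > 1000 nM, a limit and not a number. The step to it from compound 2, itself known only as a limit, cannot be read. The compounds shown leave open whether methyl in place of hydrogen on an amine nitrogen changes potency at all.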